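Same Atoms, Joined Differently: Estimating Compound 3

The compounds below may be only part of what the source reports. "The series", "measured", "known", "first", "only" and "open" are said of these compounds alone.

Of the compounds shown here, two of this set have been measured in a functional assay on HEK293 cells for positive allosteric modulation of metabotropic glutamate receptor 5 (Homo sapiens), read by calcium flux; a lower number here means a smaller maximal response, a higher number a larger maximal response. Compound 1, `O=C(c1c[nH]c2ccccc12)N1CCc2nc(COc3ccccc3)oc2C1`, gives 71%. Among the compounds with values here, compound 2, `O=C(c1n[nH]c2cccnc12)N1CCc2nc(COc3ccccc3)oc2C1`, gives 29%, the lower of the two numbers, and the single measured step, a number 42 percentage points lower from compound 1 to compound 2 (beyond the scatter), shows that exchanging the group on the carbonyl carbon can move the response a long way. Compound 3, `O=C(c1n[nH]c2ncccc12)N1CCc2nc(COc3ccccc3)oc2C1`, is still unmeasured. It differs from compound 2 by a group of 9 heavy atoms (6 carbon, 3 nitrogen; one five-membered aromatic ring with 2 hetero atoms, one six-membered aromatic ring with 1 hetero atom) in place of a group of 9 heavy atoms (6 carbon, 3 nitrogen; one five-membered aromatic ring with 2 hetero atoms, one six-membered aromatic ring with 1 hetero atom), on a carbonyl carbon; the two have the same atoms, joined differently. Within the data shown here, no measured step involves a rearrangement of this kind, so the step from compound 1 to compound 2 is only loosely related: it tells that this part of the molecule matters, not in which direction a rearranged group will move the number. A modest step of uncertain direction is therefore expected. Compound 3 is expected to reach about 40%, between 20% and 70%, an expected step of a number 11 percentage points higher from compound 2 to compound 3 (beyond the scatter) in this assay.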

Compound 3, largest response reached (reported as percent of maximum), in percent of the reference or control that the assay uses: 73%
For compound 3 the middle estimate is 33 percentage points below the measured one; the whole stated range lies below it.
By their numbers in this assay, from the lowest: compound 2; then compounds 1 and 3 (each within the scatter of the next).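

In this assay, rearranging the same atoms within the group on the carbonyl carbon is enough to shift the response, as the rearrangement gives a number 44 percentage points higher from compound 2 to compound 3 (beyond the scatter) with the counts of heavy atoms, donors and acceptors all unchanged. Within the data shown here, the group in compound 3 also holds more nitrogen than the one in compound 1, yet the comparison shows a number 2 percentage points higher from compound 1 to compound 3 (within the scatter) and so more nitrogen in this group does not in itself go with a lower response, although compound 2 alone would have suggested that it does. Nothing measured here accounts for the gap between the two arrangements.

The compounds shown leave open how a simpler group on the carbonyl carbon, such as a phenyl or a pyridine ring, would compare. They also leave open what a methyl group on the five-membered ring of compound 3 would do to the response.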